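A few compounds are considered here, and "the series" means these few. Any claim that something is new, unique, unknown or untested is made for them only; others in the source may bear on it.

Measured so far in a functional assay on UO-31 cells (Homo sapiens) for antiproliferative activity, read by sulforhodamine B assay, with a stated time of 72 h; on this read-out lower numbers stand for stronger inhibition and higher numbers for weaker inhibition:

compound 1, `Cc1cc(NS(=O)(=O)c2ccc(Nc3nncc4ccccc34)cc2)no1`: 33 nM
compound 2, `O=S(=O)(Nc1nccs1)c1ccc(Nc2nncc3ccccc23)cc1`: 12 nM

Compound 2 holds the lowest of the two numbers in this assay; its nearest neighbour is compound 1, and the step of a 2.8-fold lower number from compound 1 to compound 2 (0.44 log units; beyond the scatter) carries a 1,3-thiazol-2-yl in place of a 5-methyl-1,2-oxazol-3-yl on the sulfonamide nitrogen. Within the data shown here, that is the only measured step.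

The next compound, compound 3, is `O=S(=O)(Nc1ncccn1)c1ccc(Nc2nncc3ccccc23)cc1`. It keeps the shared core of compound 2 and differs only at the sulfonamide nitrogen: pyrimidin-2-yl in place of 1,3-thiazol-2-yl on a sulfonamide nitrogen. Among the measured compounds shown here, no measured step swaps a five-membered ring for a six-membered one at this position, so the change from compound 2 has no direct precedent. For the measured compounds named here, the one step that does bear on the position, a 2.8-fold lower number from compound 1 to compound 2 (0.44 log units; beyond the scatter), shows that exchanging the ring on the sulfonamide nitrogen moves this assay by a modest amount, and a shift of similar or smaller size is the most that can be read from it.

For compound 3 the expectation is therefore a number close to that of compound 2, with the step of a 1.5-fold higher number from compound 2 to compound 3 (0.18 log units; within the scatter) estimated to stay within the scatter. The estimate for compound 3 is 18 nM, with a range from 6 nM to 60 nM.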

Compound 3, half-maximal inhibitory concentration: 23 nM
The estimate for compound 3 lay 1.3-fold (0.11 log units) below the measured number, within the range that was stated.
By their numbers in this assay, from the lowest: compounds 2, 3 and 1 (each within the scatter of the next, the first and the last beyond it).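

In this assay, a six-membered aromatic ring is accepted on the sulfonamide nitrogen: a 1.9-fold higher number from compound 2 to compound 3 (0.28 log units; within the scatter) shows that pyrimidin-2-yl can take the place of 1,3-thiazol-2-yl without a change beyond the scatter. Compound 3 also cannot be separated from the third ring, since a 1.4-fold lower number from compound 1 to compound 3 (0.16 log units; within the scatter) stays within the scatter, even though the two five-membered rings remain apart at a 2.8-fold lower number from compound 1 to compound 2 (0.44 log units; beyond the scatter). Ring size alone therefore does not sort this short series, as compound 3 cannot be distinguished from either five-membered analogue, and no measurement at hand accounts for the readings of these three rings.

Going by these compounds, all three compounds carry an aromatic ring with 2 hetero atoms on the sulfonamide nitrogen, so it remains open whether a plain phenyl ring, a saturated ring such as piperidine or a simple methyl group would stay in this range. Also open, on these data alone, is how the pyrimidin-2-yl ring itself responds to substitution, for instance with a methyl group or an amine, on the same shared core.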